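A Methoxy Added to Compound 2

A few compounds are considered here, and "the series" means these few. Any claim that something is new, unique, unknown or untested is made for them only; others in the source may bear on it.

Compound 1 `Cn1c(N2N=C(c3ccccc3)CC2c2ccccc2)nc(-c2ccccc2)c(C#N)c1=O` — in a functional assay on MCF7 cells (Homo sapiens) for antiproliferative activity, with a stated time of 72 h (a lower number here means a stronger inhibitor, a higher number a weaker inhibitor), compound 1 gives 35400 nM.
Compound 2 `Cn1c(N2N=C(c3ccccc3)CC2c2ccccc2)nc(-c2ccc(Cl)cc2)c(C#N)c1=O` — in this assay compound 2 gives 34400 nM.

Compound 2 has the lowest of the two numbers, but its nearest neighbour, compound 1, differs only by a 1.0-fold lower number from compound 1 to compound 2 (0.01 log units; within the scatter), so the two cannot be ranked. Compound 3 `COc1ccc(C2CC(c3ccccc3)=NN2c2nc(-c3ccc(Cl)cc3)c(C#N)c(=O)n2C)cc1` is not yet measured. It differs from compound 2 by methoxy in place of hydrogen on an aromatic carbon. Within the data shown here, the only measured step, from compound 1 to compound 2, concerns a different change on a different ring and lay within the scatter; no measured step bears on a methoxy, so nothing here supports a shift in either direction. The step from compound 2 to compound 3 is therefore expected to be a 1.0-fold lower number from compound 2 to compound 3 (0.01 log units; within the scatter). On that basis compound 3 is estimated at 34000 nM, with a range from 12000 nM to 95000 nM.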

Compound 3, half-maximal inhibitory concentration: 52400 nM
The estimate for compound 3 lay 1.5-fold (0.19 log units) below the measured number; the measured number falls inside the stated range.
By their numbers in this assay, from the lowest: compounds 2, 1 and 3 (each within the scatter of the next).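

Replacing hydrogen with methoxy on an aromatic carbon, para to a large group, turns phenyl into 4-methoxyphenyl and gives a 1.5-fold higher number from compound 2 to compound 3 (0.18 log units; within the scatter) in this assay. The earlier compounds shown here showed no change on this ring, and this step shows that a methoxy here, with its 2 heavy atoms, leaves the number within the usual scatter of compound 2. No available evidence bears on this result.

With methoxy the only group shown at this position, an amine, a carboxylic acid or a longer chain such as butoxy could still give a clearly different number. The compounds shown also leave open whether methoxy would give a similar step without the chloro on the other ring, as in compound 1.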